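Moving a methyl around a phenyl ring

The source may report more compounds than this note shows. Statements on the series, on what has been measured and on what is new or still open speak of the compounds shown alone.

Measured so far:
compound 1, `CC1=NN(c2ccc(Cl)cc2)C(=O)C12C=CC(=O)C=C2c1ccccc1`, in a functional assay on MDA-MB-231 cells (Homo sapiens) for antiproliferative activity, read by CCK-8 assay, with a stated time of 72 h (on this read-out lower numbers stand for stronger inhibition and higher numbers for weaker inhibition), compound 1 gives > 100000 nM, a limit of the assay
compound 2, `CC1=NN(c2ccc(Cl)cc2)C(=O)C12C=CC(=O)C=C2c1ccc(C)cc1`, in this assay compound 2 gives 14300 nM

Compound 2 holds the only actual number shown; the other entry is a limit. For the measured compounds named here, the one measured step, an at least 6.9-fold lower number from compound 1 to compound 2 (0.84 log units; beyond the scatter), shows that methyl in place of hydrogen on an aromatic carbon brings a measurable gain, with the limit of > 100000 nM in this assay, at which 1 of the 2 values shown sits, marking where compound 1 sits.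

Compound 3, `CC1=NN(c2ccc(Cl)cc2)C(=O)C12C=CC(=O)C=C2c1cccc(C)c1`, differs from compound 2 by 3-methylphenyl in place of 4-methylphenyl on a double-bonded ring carbon. Going by the values given here, no measured step moves a methyl from one ring position to another; the only step measured adds a methyl. With nothing to point either way, the expected step is none beyond the scatter, a 1.4-fold higher number from compound 2 to compound 3 (0.15 log units; within the scatter). For compound 3 in this assay the estimate is 20000 nM, expected to lie between 6000 nM and 70000 nM.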

Compound 3, half-maximal inhibitory concentration: 26900 nM
Compound 3: middle estimate off by 1.3-fold (0.13 log units), on the low side, within the range that was stated.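

Moving the methyl from 4-methylphenyl to 3-methylphenyl gives a 1.9-fold higher number from compound 2 to compound 3 (0.27 log units; within the scatter), so in this assay these two placements cannot be told apart. Adding a methyl to the phenyl ring of compound 1 also brings a gain in this second placement, with an at least 3.7-fold lower number from compound 1 to compound 3 (0.57 log units; beyond the scatter), so the gain seen with compound 2 is not confined to 4-methylphenyl. The value of compound 1 is a limit of the assay, so both gains are minimum sizes: the limit of > 100000 nM in this assay, at which 1 of the 3 values shown sits.

Still open, on these data alone, is whether a methyl is specifically needed on this phenyl ring, or whether an ethyl, a methoxy or a chlorine in the same places would serve as well or better. An amine or a carboxylic acid on the ring would test a very different kind of group at this position.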